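One Added Chlorine, Seen Once, Expected Again

The source may hold more compounds than are shown below. What is called first, only, known or untested is meant among the compounds shown, and "the series" means these compounds.

Compound 3 `Clc1ccc(Sc2c(-c3ccc(Cl)cc3)[nH]c3ccccc23)cc1` and compound 1 `Clc1ccc(Sc2c(-c3ccc(Cl)cc3)[nH]c3ccc(Cl)cc23)cc1` differ in a single place: chloro in place of hydrogen on an aromatic carbon. In a functional assay on A549 cells (Homo sapiens) for inhibition, read by MTT assay, with a stated time of 72 h (on this read-out higher numbers stand for weaker inhibition of growth and lower numbers for stronger inhibition of growth), compound 3 gives 27000 nM, and compound 1 gives 27000 nM. The size of that step is no change at the digits printed from compound 3 to compound 1 (within the scatter). Compound 2 `CCOC(=O)C1CCN(C(=S)Sc2c(-c3ccc(Br)cc3)[nH]c3ccccc23)CC1` is built on a different core, and the difference between its core and the core of compound 3 is not broken down here. In this assay compound 2 gives 34000 nM, a number within the scatter of compound 1 and of compound 3. Compound 4 `CCOC(=O)C1CCN(C(=S)Sc2c(-c3ccc(Br)cc3)[nH]c3ccc(Cl)cc23)CC1` has not yet been measured. It arises from compound 2 by the same change that turned compound 3 into compound 1: chloro in place of hydrogen on an aromatic carbon, at a place described in identical words. Because the earlier step was no change at the digits printed from compound 3 to compound 1 (within the scatter), the expected step from compound 2 to compound 4 is no change at the digits printed from compound 2 to compound 4 (within the scatter). For compound 4 the estimate in this assay is 34000 nM, expected to fall between 15000 nM and 70000 nM. A single earlier example supports this, so the expectation is a loose one.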

Compound 4, concentration for 50% growth inhibition: 34000 nM
Beside the measured number, compound 4's estimate shows no gap at the digits printed; low and high end bracket the measured number.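

Replacing hydrogen with chloro on an aromatic carbon gives no change at the digits printed from compound 2 to compound 4 (within the scatter) in this assay and so matches the earlier step on the other core: the same change on two cores in this assay, no change at the digits printed (within the scatter) from compound 3 to compound 1 and no change at the digits printed (within the scatter) from compound 2 to compound 4, 1.0-fold (0.00 log units) apart, within the scatter of two such steps.

For these two pairs, then, the change carries over from one core to the other, and the result on one core would have predicted the result on the other. What carries over, however, is a step too small to read, so this does not show how the two cores would compare for a change that really shifts the number. Two pairs also make no rule for the whole series.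

The compounds shown leave open whether a different group at this same place, such as an amine, a carboxylic acid or a longer carbon chain, would give a step beyond the scatter. They also leave open whether chloro would give the same result on any further core.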